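Compound 2 at the limit: one group exchanged

The source may hold more compounds than are shown below. What is called first, only, known or untested is meant among the compounds shown, and "the series" means these compounds.

Measured in a functional assay on MDA-MB-231 cells (Homo sapiens) for antiproliferative activity, read by MTT assay, with a stated time of 72 h; a higher number here means a weaker inhibitor, a lower number a stronger inhibitor:
- compound 1 (`O=C(Nc1ccc(-c2noc(-c3cccc(NS(=O)(=O)c4ccccc4)c3)n2)c(Cl)c1)c1cccnc1`) gives > 10000 nM (a limit)
- compound 2 (`Cc1ccc(S(=O)(=O)Nc2cccc(-c3nc(-c4ccc(NC(=O)c5cccnc5)cc4Cl)no3)c2)cc1`) gives > 10000 nM (a limit)

Compound 2 records > 10000 nM and this is a limit, not a number. For the measured compounds named here, the same holds for the whole series so far: the limit of > 10000 nM in this assay, at which 2 of the 2 values shown sit, is all that can be said. Going by the values given here, the only measured step is a step that the two limits leave unreadable from compound 1 to compound 2 and so it offers no size to carry forward.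

Compound 3 (`O=C(Nc1ccccc1)Nc1cccc(-c2nc(-c3ccc(NC(=O)c4cccnc4)cc3Cl)no2)c1`) has phenylcarbamoyl in place of (4-methylphenyl)sulfonyl on a nitrogen on an aromatic ring. With no readable step behind it, no particular size or direction of change can be expected in this assay and a result near the limit seems most likely. The expected move is a step that the limit leaves unreadable from compound 2 to compound 3 and it is only a rough estimate. For compound 3 the estimated value is 12000 nM with an expected range from 4000 nM to 30000 nM and another limit would be no surprise.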

Compound 3, half-maximal inhibitory concentration: > 10000 nM
Compound 3 ended at the assay's limit (the forecaster's own chance of this, stated with the estimate: 70%); the middle value does not contradict the limit.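

Compound 3 also ends at a limit rather than a number, so neither step to it, from compound 1 or from compound 2, can be read: the limit of > 10000 nM in this assay, at which 3 of the 3 values shown sit.

The compounds shown leave open whether any group on this nitrogen gives a measurable value in this assay.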